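Enlarging the ring on the amine nitrogen

A few compounds are considered here, and "the series" means these few. Any claim that something is new, unique, unknown or untested is made for them only; others in the source may bear on it.

In an in vitro ADME assay on microsomes from liver (Mus musculus) for pharmacokinetics, read by LC-MS, with a stated time of 10 min, tested at 1 uM (a lower number here means slower removal, a higher number faster removal of the compound), compound 1 `CN1C[C@H](C(=O)Nc2ccc(C#N)cc2)[C@@H](c2ccc(/C=C/C(=O)Nc3ccccc3N)cc2)C1` gives 35 mL/min/kg and compound 2 `Nc1ccccc1NC(=O)/C=C/c1ccc([C@H]2CN(C3COC3)C[C@@H]2C(=O)Nc2ccc(Cl)cc2)cc1` gives 42 mL/min/kg. These two numbers lie within the usual scatter of each other, so compound 2 stands level with compound 1 on clearance. The unmeasured compound 3 `Nc1ccccc1NC(=O)/C=C/c1ccc([C@H]2CN(C3CCOCC3)C[C@@H]2C(=O)Nc2ccc(Cl)cc2)cc1` keeps all of compound 2 except one group: it carries oxan-4-yl in place of oxetan-3-yl on an amine nitrogen in a ring. Among the measured compounds shown here, no pair of measured compounds differs in one place only, so the data hold no direct guide to this swap. A small upward move is expected, one that stays within the scatter. The estimated step of a 1.2-fold higher number from compound 2 to compound 3 (0.08 log units; within the scatter) is therefore modest. For compound 3 the expected clearance is 50 mL/min/kg, with an estimated range of 28 mL/min/kg to 90 mL/min/kg.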

Compound 3, clearance: 44 mL/min/kg
For compound 3 the middle estimate is 1.1-fold (0.06 log units) above the measured one; low and high end bracket the measured number.
By their numbers in this assay, from the lowest: compounds 1, 2 and 3 (each within the scatter of the next).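

In this assay, among the compounds shown here, the swap gives a 1.0-fold higher number from compound 2 to compound 3 (0.02 log units; within the scatter), and this is the first comparison here that changes this position alone. It shows that, with the (4-chlorophenyl)carbamoyl group held constant, a six-membered non-aromatic ring with one oxygen and a four-membered one on the amine nitrogen in a ring cannot be told apart by clearance. No measurement at hand accounts for this result.

Both groups are oxygen-containing rings, so these compounds leave open whether a group of another kind, such as a piperidin-4-yl ring with its amine or an open chain like 2-methoxyethyl, would give a clearance beyond the scatter. They also leave open whether the same swap would read alike with a different group on the amide.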